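Nitro in Place of Chloro: Compound 3 to Compound 4

A few compounds are considered here, and "the series" means these few. Any claim that something is new, unique, unknown or untested is made for them only; others in the source may bear on it.

Compound 1 `O=c1cc(Cn2cc(CCO)nn2)c2ccc(O)cc2o1` gives > 100000 nM in a functional assay on CFPAC-1 cells (Homo sapiens) for inhibition, read by MTT assay, with a stated time of 72 h (a lower number here means a stronger inhibitor, a higher number a weaker inhibitor), which is a limit of the assay.
Compound 2 `O=c1cc(Cn2cc(-c3cc(F)cc(F)c3)nn2)c2ccc(O)cc2o1` gives > 100000 nM in this assay, also a limit.
Compound 3 `O=c1cc(Cn2cc(CNS(=O)(=O)c3ccc(Cl)cc3)nn2)c2ccc(O)cc2o1` gives 81900 nM in this assay.

Within the data shown here, compound 3 therefore stands as the only actual number among the three values, the others sitting at the limit of > 100000 nM in this assay, at which 2 of the 3 values shown sit. Among the measured compounds shown here, the one measured step, a step that the two limits leave unreadable from compound 1 to compound 2, cannot be sized from its two limits and does not touch the sulfonamide aryl group. Compound 4 `O=c1cc(Cn2cc(CNS(=O)(=O)c3ccc([N+](=O)[O-])cc3)nn2)c2ccc(O)cc2o1` differs from compound 3 by nitro in place of chloro on an aromatic carbon. For the measured compounds named here, no measured step bears on this change, so no shift beyond the scatter is expected in this assay. Compound 4 is estimated at 80000 nM, between 30000 nM and 200000 nM, an expected step of a 1.0-fold lower number from compound 3 to compound 4 (0.01 log units; within the scatter).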

Compound 4, half-maximal inhibitory concentration: > 100000 nM
Compound 4: only a limit was reported; the forecaster's own chance of this, stated with the estimate: 35%; middle value at least 1.2-fold (0.09 log units) from the limit.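

In this assay, 4-nitrophenyl in place of 4-chlorophenyl gives an at least 1.2-fold higher number from compound 3 to compound 4 (0.08 log units; that floor lies within the scatter). Among these compounds, this is the only readable step at the sulfonamide aryl group, and it has a floor but no full size, since the value of compound 4 is a limit. Compound 3 thus remains the only compound here with an actual number: the limit of > 100000 nM in this assay, at which 3 of the 4 values shown sit.

On these data alone, whether an amine or a carboxylic acid on that aromatic carbon would give a number lower than that of compound 3, 81900 nM, stays open. So does the effect of a longer chain between the sulfonamide and the triazole.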